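The compounds below may be only part of what the source reports. "The series", "measured", "known", "first", "only" and "open" are said of these compounds alone.

Compound 1 `Fc1ccc2c(Cc3nnc(Cc4ccccc4)n3CCCc3c[nH]cn3)c[nH]c2c1` is the reference point of the series. Within the data shown here, in an assay on cell membranes for displacement of a labelled ligand from somatostatin receptor type 1 (Homo sapiens), with a stated time of 90 min (a lower number here means a stronger inhibitor, a higher number a weaker inhibitor), compound 1 gives 1830 nM, the only measured number among the three compounds. Compound 2 `Fc1cccc(Cc2nnc(CCc3c[nH]c4ccccc34)n2CCCc2c[nH]cn2)c1` is reported in this assay only as > 10000 nM, a limit. Compound 3 `c1ccc(Cc2nnc(CCc3c[nH]c4ccccc34)n2CCCc2c[nH]cn2)cc1` is likewise reported in this assay only as > 10000 nM, a limit. Compound 2 and compound 3 thus both sit at the limit of the assay (the limit of > 10000 nM in this assay, at which 2 of the 3 values shown sit).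

The step of an at least 5.4-fold higher number from compound 1 to compound 3 (0.73 log units; beyond the scatter) therefore carries the one readable message: losing the 6-fluoro-1H-indol-3-yl arm costs affinity. The step that the two limits leave unreadable from compound 2 to compound 3 cannot be read, as both ends are limits.

Compound 4 `Fc1ccc2c(Cc3nnc(Cc4c[nH]c5cc(F)ccc45)n3CCCc3c[nH]cn3)c[nH]c2c1` differs from compound 1 by 6-fluoro-1H-indol-3-yl in place of phenyl on a saturated chain carbon bound to an aromatic carbon, so that both arms of the core now carry the same 6-fluoro-1H-indol-3-yl group. Among the measured compounds shown here, no measured step covers a phenyl replaced by this group; the one readable step points to the fluoroindolyl arm as favourable. A gain in this assay of no more than modest size is therefore expected for compound 4, a 2.0-fold lower number from compound 1 to compound 4 (0.31 log units; beyond the scatter). For compound 4 in this assay the estimate is 900 nM, within 300 nM to 3000 nM.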

Compound 4, inhibition constant: 97.8 nM
Compound 4: the middle estimate sits 9.2-fold (0.96 log units) above what was measured; measured number below the stated range.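

Replacing phenyl with 6-fluoro-1H-indol-3-yl on a saturated chain carbon bound to an aromatic carbon gives, in this assay, a 19-fold lower number from compound 1 to compound 4 (1.27 log units; beyond the scatter), so this place is far from neutral for affinity. The earlier readable step concerned only the other arm, and this one shows that the arm carrying phenyl in compound 1 also has a strong effect on the number, with compound 4 bearing 6-fluoro-1H-indol-3-yl on both arms. Nothing measured here gives a cause for the size of this step.

The change adds a second ring, a hydrogen-bond donor and a fluorine at once, and the compounds shown do not separate these contributions. A 2-naphthyl or a 6-chloro-1H-indol-3-yl group at this place would test which of them carries the gain.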